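A few compounds are considered here, and "the series" means these few. Any claim that something is new, unique, unknown or untested is made for them only; others in the source may bear on it.

Compound 1, with the structure `CC(C)=CCCC1=CC[C@H](C(=O)Nc2ccc(O)cc2)[C@@H](c2ccccc2)C1`, was tested in an assay on isolated protein for inhibition of Apoptosis regulator Bcl-2 (Homo sapiens), read by fluorescence polarization, with stated times of 5 min and 10 min; on this read-out lower numbers stand for stronger inhibition and higher numbers for weaker inhibition. In this test compound 1 gives only a limit of the assay, > 23000 nM, and not a number. Two related compounds are known from the same test. Compound 2, `CON(C)C(=O)[C@H]1CC2=C(CCCC2(C)C)C[C@@H]1c1ccccc1`, likewise gives only a limit, > 23000 nM. Compound 3, `COC(=O)CCNC(=O)[C@@H]1CC=C(CCC=C(C)C)C[C@H]1c1ccccc1`, also gives only a limit, > 23000 nM. So compound 1 stands together with the other two at the limit of > 23000 nM in this assay, at which 3 of the 3 values shown sit, and none of the three shows measurable inhibition.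

Compound 4, `CONC(=O)[C@H]1CC=C(CCC=C(C)C)C[C@@H]1c1ccccc1`, has not yet been tested. It differs from compound 1 in one place: methoxy in place of 4-hydroxyphenyl on an amide-type nitrogen. No pair of measured compounds shows the effect of this change, so the size of the step cannot be read from the numbers shown. Compound 1 sits at the limit, and compound 2 sits there too. Compound 4 is therefore expected to remain at the limit as well, with a step that the limit leaves unreadable from compound 1 to compound 4 of no size beyond the scatter. The estimated value of compound 4 in this assay is 30000 nM, expected to lie between 15000 nM and 100000 nM.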

Compound 4, inhibition constant: 2400 nM
Compound 4: the middle estimate sits 13-fold (1.10 log units) above what was measured, and the stated range ends above it.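

In this assay, the group on the amide-type nitrogen turns out to matter: methoxy in place of 4-hydroxyphenyl gives an at least 9.5-fold lower number from compound 1 to compound 4 (0.98 log units; beyond the scatter), and compound 4 is the only compound shown that yields a number and not a limit. On this nitrogen, then, the six-membered aromatic ring is not needed for measurable inhibition, and a much smaller group with no ring can serve. The step can only be given as a minimum, because compound 1 gives a limit and not a number: the limit of > 23000 nM in this assay, at which 3 of the 4 values shown sit.

On these data alone, what stays open is whether the gain depends on the oxygen of the methoxy or comes simply from losing the 4-hydroxyphenyl. A plain methyl, an ethoxy or a free hydroxyl on the same nitrogen would help to separate these two readings.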